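Methyl in place of hydrogen on compound 2

A few compounds are considered here, and "the series" means these few. Any claim that something is new, unique, unknown or untested is made for them only; others in the source may bear on it.

Compound 2 `Cc1ccccc1S(=O)(=O)n1c(=O)[nH]c2ccc(Cl)cc21` is the starting point of this step. In an ADME assay on MT4 cells (Homo sapiens) for cytotoxicity (on this read-out higher numbers stand for lower toxicity in this test and lower numbers for higher toxicity in this test), compound 2 gives > 387000 nM, which is a limit and not a number. Compound 3 `Cc1cccc(S(=O)(=O)n2c(=O)[nH]c3ccc(Cl)cc32)c1` gives > 307000 nM, also a limit. Compound 1 `Cc1cc(C)cc(S(=O)(=O)n2c(=O)[nH]c3ccc(Cl)nc32)c1` gives > 272000 nM, again a limit. With all three readings reported only as limits, compound 2 cannot be ranked against the other two.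

Compound 4 `Cc1ccc(S(=O)(=O)n2c(=O)[nH]c3ccc(Cl)cc32)c(C)c1` differs from compound 2 in one place: methyl in place of hydrogen on an aromatic carbon. The incoming methyl sits on an aromatic carbon of a six-membered aromatic ring of carbon only, meta to a methyl group and para to a large group.

Within the data shown here, the one measured step that bears on this change is a step that the two limits leave unreadable from compound 2 to compound 3, with 3-methylphenyl in place of 2-methylphenyl on a sulfonyl sulfur. It offers no size to carry over, so the expectation rests on all three compounds remaining limits in this assay. No step beyond the scatter is expected in either direction, and compound 4 will most likely also be reported as a limit. The expected result is an at least 1.2-fold lower number from compound 2 to compound 4 (0.08 log units; that floor lies within the scatter). The estimated value for compound 4 is 320000 nM, with an expected range of 150000 nM to 400000 nM.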

Compound 4, half-maximal cytotoxic concentration: 39300 nM
Estimate against measurement, compound 4: 8.1-fold (0.91 log units) above, outside the stated range (below it).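

In this assay, among these compounds, methyl in place of hydrogen on an aromatic carbon, meta to a methyl group and para to a large group, gives an at least 9.8-fold lower number from compound 2 to compound 4 (0.99 log units; beyond the scatter) and so provides the first step of readable size in this small set, pointing towards higher toxicity in this test. Among the compounds shown here, compound 4, at 39300 nM, is the only compound here with a number and not a limit, which shows that a single added methyl at this position can be enough to bring the series into the measurable range of the read-out. Compound 2 stands at a limit, so the true size of this step is open on the upper side and only its floor is known: the limit of > 387000 nM in this assay, at which 1 of the 4 values shown sits.

Going by these compounds, the steps between the compounds that stand at limits cannot be read, so the effect of moving a methyl around this ring remains unknown. On these data alone, it also remains open whether the lower number is specific to methyl at this aromatic carbon or would also appear with an ethyl chain, a methoxy group, an amine or a carboxylic acid there.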